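Urea back to amide, with an added chlorine

The source may hold more compounds than are shown below. What is called first, only, known or untested is meant among the compounds shown, and "the series" means these compounds.

Compound 1 `COc1cc(-c2nn(-c3cccc(NC(=O)c4cccc(C(F)(F)F)c4)c3)cc2-c2ccncc2)ccc1Cl` gives > 50000 nM in a functional assay on RXF 393 cells (Homo sapiens) for inhibition, read by sulforhodamine B assay, with a stated time of 48 h; a lower number here means that less compound is tolerated, a higher number that more compound is tolerated; that value is a limit of the assay, not a number.
Compound 2 `COc1cc(-c2nn(-c3cccc(NC(=O)Nc4cccc(C(F)(F)F)c4)c3)cc2-c2ccncc2)ccc1Cl` gives 4830 nM in this assay.

Within the data shown here, compound 2 thus holds the only number here, the other entry being (the limit of > 50000 nM in this assay, at which 1 of the 2 values shown sits). Compound 3 `COc1cc(-c2nn(-c3cccc(NC(=O)c4ccc(Cl)c(C(F)(F)F)c4)c3)cc2-c2ccncc2)ccc1Cl` differs from compound 2 by 4-chloro-3-(trifluoromethyl)phenyl in place of (3-(trifluoromethyl)phenyl)amino on a carbonyl carbon. Among the measured compounds shown here, the one measured step, an at least 10-fold lower number from compound 1 to compound 2 (1.01 log units; beyond the scatter), runs the opposite way through the same carbonyl and was large; the added chlorine has no measured counterpart. A large rise back toward the limit is therefore expected, a 6.2-fold higher number from compound 2 to compound 3 (0.79 log units; beyond the scatter). Compound 3 is estimated at 30000 nM, within 8000 nM to 100000 nM.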

Compound 3, concentration lethal to 50% of the cells: > 32500 nM
Compound 3: a limit, no number; the forecaster's own chance of this, stated with the estimate: 50%; middle value at least 1.0-fold (0.03 log units) away from the limit.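

In this assay, replacing the (3-(trifluoromethyl)phenyl)amino group with 4-chloro-3-(trifluoromethyl)phenyl gives an at least 6.7-fold higher number from compound 2 to compound 3 (0.82 log units; beyond the scatter), so the added chloro does not bring the amide back to the urea's level. Compound 3 stands at a limit of the assay, not a number: the limit of > 32500 nM in this assay, at which 1 of the 3 values shown sits.
Compound 1, the amide without the chloro, also stands at a limit: the limit of > 50000 nM in this assay, at which 1 of the 3 values shown sits.

Going by these compounds, these two limits leave the step from compound 1 to compound 3 unreadable, so the effect of the chloro alone stays open. Also open, on these data alone, is how a urea would fare with a chloro or a methoxy on its trifluoromethyl-bearing ring.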